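Amide aryl change: from compound 2 to compound 3

The source may report more compounds than this note shows. Statements on the series, on what has been measured and on what is new or still open speak of the compounds shown alone.

Compound 1 `O=C(Nc1cccc(-c2oc3cc(-c4ccc(F)cc4)ccc3c(=O)c2O)c1)c1ccc(F)cc1F` gives 11200 nM in a functional assay on MDA-MB-231 cells (Homo sapiens) for antiproliferative activity, read by CCK-8 assay, with a stated time of 72 h; on this read-out higher numbers stand for weaker inhibition and lower numbers for stronger inhibition. For the measured compounds named here, compound 2 `O=C(Nc1cccc(-c2oc3cc(-c4ccc(F)cc4)ccc3c(=O)c2O)c1)c1cccc(F)c1` gives 2510 nM in this assay, the lowest of the two numbers so far, with the only measured step being a 4.5-fold lower number from compound 1 to compound 2 (0.65 log units; beyond the scatter). Compound 3 `O=C(Nc1cccc(-c2oc3cc(-c4ccc(F)cc4)ccc3c(=O)c2O)c1)c1ccc([N+](=O)[O-])cc1` is not yet measured; it differs from compound 2 by 4-nitrophenyl in place of 3-fluorophenyl on a carbonyl carbon. Going by the values given here, the single step that bears on this position is a 4.5-fold lower number from compound 1 to compound 2 (0.65 log units; beyond the scatter), which swapped one fluorinated aryl for another on the same carbonyl carbon and moved the number modestly. Nothing measured shows how a nitro-bearing aryl on that carbonyl carbon behaves, so no direction can be anchored. A step of about the same size as the measured one, in either direction, is the widest expectation justified; the central expectation is a number near that of compound 2. For compound 3 the value in this assay is estimated at 3500 nM, within 1000 nM to 12000 nM, meaning an expected step of a 1.4-fold higher number from compound 2 to compound 3 (0.14 log units; within the scatter).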

Compound 3, half-maximal inhibitory concentration: 14700 nM
Compound 3: the middle estimate sits 4.2-fold (0.62 log units) below what was measured; measured number above the stated range.
By their numbers in this assay, from the lowest: compound 2; then compounds 1 and 3 (each within the scatter of the next).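

In this assay the 4-nitrophenyl amide loses what the 3-fluorophenyl amide gained, with a 5.9-fold higher number from compound 2 to compound 3 (0.77 log units; beyond the scatter) on the carbonyl carbon whose other neighbour is the amide-type nitrogen. With a 1.3-fold higher number from compound 1 to compound 3 (0.12 log units; within the scatter), compound 3 and compound 1 cannot be told apart, so the number at this position changes with the aryl group, and among the three aryl groups shown only compound 2 stands apart, at 2510 nM. Nothing available accounts for this difference between the aryl groups.

As far as these compounds go, whether a 3-nitrophenyl group would behave like 3-fluorophenyl or like 4-nitrophenyl remains open, since compound 2 and compound 3 differ in both the substituent and its place on the ring. Also open, from the compounds shown here alone, is how an aminophenyl or carboxyphenyl group on this carbonyl carbon would compare with compound 2.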